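A few compounds are considered here, and "the series" means these few. Any claim that something is new, unique, unknown or untested is made for them only; others in the source may bear on it.

Working notes on the series.

Two compounds carry values in a functional assay on L02 cells (Homo sapiens) for inhibition, read by Griess assay, with stated times of 1 h and 24 h (a higher number here means a weaker inhibitor, a lower number a stronger inhibitor), so far, and neither is a number. Compound 1 `CCCc1nn(C)c2c(NCc3ccc(F)cc3)nc(/C=C/c3nc(C)c(C)nc3C)nc12` reaches only the upper end of the range measured: in this assay compound 1 gives > 1000000 nM, a limit of the assay (the limit of > 1000000 nM in this assay, at which 1 of the 2 values shown sits). Compound 2 `COc1cc(/C=C/c2nc(Nc3ccc(C)cc3)c3sccc3n2)cc(OC)c1OC` sits at the opposite end: in this assay compound 2 gives < 40000 nM, again a limit rather than a number (the limit of < 40000 nM in this assay, at which 1 of the 2 values shown sits). Among the compounds with values here, compound 2 therefore stands as the stronger of the two, but its position is known only as a bound, and no step between measured compounds is available in this set.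

Compound 3 `COc1cc(/C=C/c2nc(NC(C)C)c3sccc3n2)cc(OC)c1OC` differs from compound 2 in one place: isopropyl in place of 4-methylphenyl on a nitrogen on an aromatic ring. Within the data shown here, with no measured step to lean on, the step from compound 2 to compound 3 is expected to be a number no lower from compound 2 to compound 3 (the limit leaves the size open), a small loss not clearly beyond the scatter. Compound 3 is estimated at 40000 nM, with a range of 10000 nM to 150000 nM.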

Compound 3, half-maximal inhibitory concentration: > 1000000 nM
Compound 3: a limit, no number (the forecaster's own chance of this, stated with the estimate: 50%); middle value at least 25-fold (1.39 log units) away from the limit.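

Within the data shown here, on a nitrogen on an aromatic ring, isopropyl in place of 4-methylphenyl gives an at least 25-fold higher number from compound 2 to compound 3 (1.39 log units; beyond the scatter) in this assay and so provides the first measured step. This position is therefore not indifferent to the group it carries: with 4-methylphenyl the compound stays on the stronger side of the series, and with isopropyl it does not. Compound 3 gives > 1000000 nM as a limit and not a number, so the step has a lower bound only: the limit of > 1000000 nM in this assay, at which 2 of the 3 values shown sit.

From the compounds shown here alone, whether the aromatic ring itself matters on that nitrogen stays open, and a cyclohexyl group or a phenyl without the methyl at this place would separate the two readings. Going by these compounds, how far compound 2 lies beyond its own limit also stays open, so the true size of the step remains unknown.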